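Swapping an Aromatic Ring for a Saturated One

The source may report more compounds than this note shows. Statements on the series, on what has been measured and on what is new or still open speak of the compounds shown alone.

Two compounds have so far been measured in a functional assay for inhibition of Polyunsaturated fatty acid 5-lipoxygenase (Homo sapiens); on this read-out lower numbers stand for stronger inhibition and higher numbers for weaker inhibition:
compound 1, `O=C(O)/C(CSCCO)=N/OC(c1ccc(OCc2ccc3ccccc3n2)cc1)C1CCCCC1`, gives 181 nM;
compound 2, `O=C(O)/C(=N/OC(c1ccc(OCc2ccc3ccccc3n2)cc1)C1CCCCC1)c1ccccc1`, gives 31 nM.

For the measured compounds named here, of these two numbers, compound 2 holds the lower one, and the only measured step, a 5.8-fold lower number from compound 1 to compound 2 (0.77 log units; beyond the scatter), lies beyond the usual scatter, so compound 2 stands clearly ahead of compound 1 on this read-out.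

Compound 3, `O=C(O)C1CCC(=NOC(c2ccc(OCc3ccc4ccccc4n3)cc2)C2CCCCC2)CC1`, has not yet been measured. It differs from compound 2 in one place: a group of 10 heavy atoms (7 carbon, 1 nitrogen, 2 oxygen; one six-membered non-aromatic ring of carbon only) in place of a group of 11 heavy atoms (8 carbon, 1 nitrogen, 2 oxygen; one six-membered aromatic ring of carbon only), on an oxygen on a saturated carbon. Going by the values given here, the single measured step bears on this change only indirectly, since it showed a modest gain on going from a chain to a phenyl on the carbon doubly bonded to nitrogen, whereas compound 3 keeps neither of those groups and exchanges the aromatic ring for a non-aromatic one. A modest shift toward higher numbers in this assay is therefore expected, smaller than the step already seen. For compound 3 the estimated value is 80 nM, with a range from 25 nM to 300 nM, which corresponds to an expected step of a 2.6-fold higher number from compound 2 to compound 3 (0.41 log units; beyond the scatter).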

Compound 3, half-maximal inhibitory concentration: 67 nM
Beside the measured number, compound 3's estimate is 1.2-fold (0.08 log units) above it; measured number inside the range.
By their numbers in this assay, from the lowest: compound 2; then compound 3; then compound 1.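

In this assay, the new result shows that the group on this oxygen need not carry an aromatic ring to keep much of its strength: replacing the aromatic ring with a six-membered non-aromatic ring of carbon only gives a 2.2-fold higher number from compound 2 to compound 3 (0.33 log units; beyond the scatter), a modest loss. Measured against the group with no ring, the non-aromatic ring still gives a 2.7-fold lower number from compound 1 to compound 3 (0.43 log units; beyond the scatter); together with the earlier step, this places both ring-bearing groups ahead of the open chain on this read-out, and no compound shown goes against that order. Nothing available on these compounds speaks to what lies behind either step.

The compounds shown leave open whether a piperidine ring, which puts a nitrogen into the six-membered ring, or a smaller cyclopentane ring would hold a number close to that of compound 3 at this place. All three compounds also carry a carboxylic acid, so they leave open what an amide or an ester in its place would do to the read-out.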